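Working notes: 3-cyanophenyl in place of 4-methylphenyl

The compounds below may be only part of what the source reports. "The series", "measured", "known", "first", "only" and "open" are said of these compounds alone.

In an ADME assay on HUVEC cells (Homo sapiens) for inhibition, read by CCK-8 assay, with a stated time of 24 h, in the presence of a further agent that is not named here (on this read-out lower numbers stand for stronger inhibition and higher numbers for weaker inhibition), the measured compounds give
Compound 1 `Cc1ccccc1-n1cc(-c2ccc(C=C3C(=O)Nc4ccc(F)cc43)cc2)nn1` with 8630 nM
Compound 2 `Cc1ccc(-n2cc(-c3ccc(/C=C4\C(=O)Nc5ccc(F)cc54)cc3)nn2)cc1` with 13800 nM

Compound 2 at 13800 nM lies within the scatter of compound 1 at 8630 nM and cannot be separated from it on these numbers. Compound 3 `N#Cc1cccc(-n2cc(-c3ccc(/C=C4\C(=O)Nc5ccc(F)cc54)cc3)nn2)c1` is not yet measured. Its change from compound 2 is 3-cyanophenyl in place of 4-methylphenyl on an aromatic nitrogen and reads as 3-cyanophenyl in place of 4-methylphenyl on an aromatic nitrogen. For the measured compounds named here, no measured step covers this change in this assay and so no firm direction can be given. No step beyond the scatter is expected, and the estimated move, a 1.4-fold lower number from compound 2 to compound 3 (0.14 log units; within the scatter), leans slightly to a lower number. For compound 3 the estimated value is 10000 nM with an expected range from 4000 nM to 25000 nM as a working figure.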

Compound 3, half-maximal inhibitory concentration: > 20000 nM
Compound 3 was reported as a limit; the forecaster's own chance of this, stated with the estimate: 5%; middle value at least 2.0-fold (0.30 log units) away from the limit.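

In this assay compound 3 gives > 20000 nM, which is a limit of the assay and not a number. For the compounds shown here, this is the first measured step on this aromatic nitrogen, and 3-cyanophenyl in place of 4-methylphenyl brings no lower number there. The step reads an at least 1.4-fold higher number from compound 2 to compound 3 (0.16 log units; that floor lies within the scatter), and it is only a floor, so the true size of the change stays unread: the limit of > 20000 nM in this assay, at which 1 of the 3 values shown sits.

From the compounds shown here alone, whether compound 3 truly lies beyond the scatter of compound 2 stays open. Also open, going by these compounds, is whether an amine or a carboxylic acid on this phenyl ring would give a measurable number.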